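Acetyl in place of formyl on the aryl substituent

This account rests on a few compounds, and the source may have more. Where it says the series, first, only, none or still open, it means among the compounds named here.

compound 1 `Brc1cn2ccnc2c(-c2ccc3ncn(C4CCCCC4)c3c2)n1` — 8.09%
compound 2 `O=Cc1ccc(-c2cn3ccnc3c(-c3ccc4ncn(C5CCCCC5)c4c3)n2)cc1` — 14.4%
compound 3 `c1ccc2c(-c3cn4ccnc4c(-c4ccc5ncn(C6CCCCC6)c5c4)n3)cccc2c1` — 9.08%

All three were run in a functional assay on SNB-19 cells (Homo sapiens) for inhibition, read by sulforhodamine B assay, with a stated time of 48 h, tested at 10 uM; on this read-out lower numbers stand for less inhibition and higher numbers for more inhibition at the one concentration tested (going by the name of the read-out). Compound 2 gives 14.4%; the gaps a number 6.3 percentage points higher from compound 1 to compound 2 (within the scatter) and a number 5.3 percentage points lower from compound 2 to compound 3 (within the scatter) both lie within the scatter, so nothing separates the three on these numbers. Compound 4 `CC(=O)c1ccc(-c2cn3ccnc3c(-c3ccc4ncn(C5CCCCC5)c4c3)n2)cc1` differs from compound 2 by methyl in place of hydrogen on a carbonyl carbon. Among the compounds with values here, no measured step makes this exact change. The two steps at this position, a number 6.3 percentage points higher from compound 1 to compound 2 (within the scatter) and a number 5.3 percentage points lower from compound 2 to compound 3 (within the scatter), exchange bromo for whole aryl groups and still stay within the scatter; a change of a single carbon on the carbonyl carbon is therefore expected to move the read-out no further than the scatter. Compound 4 is expected to give 14%, between 4% and 26%. From compound 2 the expected step is a number 0.4 percentage points lower from compound 2 to compound 4 (within the scatter).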

Compound 4, a percentage reported as inhibition, at one concentration (the size of the read-out at that concentration, not a potency): 3.96%
Estimate against measurement, compound 4: 10 percentage points above; measured number below the stated range.
By their numbers in this assay, from the lowest: compounds 4, 1, 3 and 2 (each within the scatter of the next, the first and the last beyond it).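

In this assay methyl in place of hydrogen on a carbonyl carbon gives a number 10.4 percentage points lower from compound 2 to compound 4 (beyond the scatter) and is the only step among these compounds that separates two of them, although the exchanges of whole groups at the aromatic carbon separated none. Compound 4 stays unresolved from the other two, with a number 5.1 percentage points lower from compound 3 to compound 4 (within the scatter) and a number 4.1 percentage points lower from compound 1 to compound 4 (within the scatter) as its remaining steps. Nothing measured here bears on the reason for this step.

Going by these compounds, whether a longer chain on the carbonyl carbon, such as propanoyl, follows acetyl stays open. So does the outcome for a carboxylic acid or an amide in place of formyl.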